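Thiophene in place of furan on the anilide of compound 2

The source may report more compounds than this note shows. Statements on the series, on what has been measured and on what is new or still open speak of the compounds shown alone.

Compound 1 `O=C(/C=C/c1ccccc1)c1ccc(NC(=O)c2cccs2)cc1` and compound 2 `O=C(/C=C/c1cccc([N+](=O)[O-])c1)c1ccc(NC(=O)c2ccco2)cc1` have been measured in a functional assay on HT-29 cells (Homo sapiens) for cytotoxicity, read by resazurin assay, with a stated time of 48 h; a higher number here means that more compound is needed for the effect, a lower number that less compound is needed. Compound 1 gives 28000 nM in this assay. Compound 2 gives 3500 nM, the lower of the two numbers, with compound 1 standing beyond the scatter above it. Compound 3 `O=C(/C=C/c1cccc([N+](=O)[O-])c1)c1ccc(NC(=O)c2cccs2)cc1` is not yet measured in this assay. It differs from compound 2 by thiophen-2-yl in place of furan-2-yl on a carbonyl carbon. Going by the values given here, no pair of measured compounds differing in one place shows such an exchange. The step of no change at the digits printed from compound 2 to compound 3 (within the scatter) is expected to remain within the scatter, in no clear direction. Compound 3 is estimated at 3500 nM, in a range from 1500 nM to 8000 nM.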

Compound 3, half-maximal effective concentration: 2500 nM
Compound 3: the middle estimate sits 1.4-fold (0.15 log units) above what was measured, and the stated range covers the measured number.
By their numbers in this assay, from the lowest: compounds 3 and 2 (each within the scatter of the next); then compound 1.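

In this assay, thiophen-2-yl in place of furan-2-yl on a carbonyl carbon gives a 1.4-fold lower number from compound 2 to compound 3 (0.15 log units; within the scatter) and so leaves the number at this position effectively unchanged in the presence of the nitro group. Nitro in place of hydrogen on an aromatic carbon gives an 11-fold lower number from compound 1 to compound 3 (1.05 log units; beyond the scatter) and shows that the series responds clearly to this change. Nothing measured here bears on the cause of either step.

As far as these compounds go, whether furan-2-yl and thiophen-2-yl also match without the nitro group remains open. Also open, from the compounds shown here alone, is whether an amine or a carboxylic acid in place of nitro would keep the number of compound 3.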